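Swapping (thiophen-2-yl)methyl for cyclohexyl on an amide-type nitrogen

The source may report more compounds than this note shows. Statements on the series, on what has been measured and on what is new or still open speak of the compounds shown alone.

Going by the values given here, in a functional assay on HEY cells (Homo sapiens) for cytotoxicity, read by MTT assay, with a stated time of 72 h (on this read-out higher numbers stand for weaker inhibition and lower numbers for stronger inhibition), compound 3 `N[C@H]1CC[C@H](Nc2c(C(=O)NCc3cccs3)nc(Br)c3cccnc23)CC1` gives 11000 nM as the only measured number that is not a limit. Compound 1 `C[C@H](NC(=O)c1nc(Br)c2cccnc2c1N[C@H]1CC[C@H](N)CC1)c1ccc(F)cc1` gives > 10000 nM and this is a limit. Compound 2 `N[C@H]1CC[C@H](Nc2c(C(=O)NCc3ccccn3)nc(Br)c3cccnc23)CC1` gives > 20000 nM and this too is a limit. Compound 4 `N[C@H]1CC[C@H](Nc2c(C(=O)NC3CCCCC3)nc(Br)c3cccnc23)CC1` carries cyclohexyl in place of the (thiophen-2-yl)methyl of compound 3 on an amide-type nitrogen (cyclohexyl in place of (thiophen-2-yl)methyl on an amide-type nitrogen). The most informative change at this nitrogen is an at least 1.8-fold lower number from compound 2 to compound 3 (0.25 log units; that floor lies within the scatter) and it stays within the scatter. The other two changes there are a step that the two limits leave unreadable from compound 1 to compound 2 and a step that the limit leaves unreadable from compound 1 to compound 3 and neither offers a size. No step beyond the scatter is therefore expected in this assay and the expected change is a 1.1-fold higher number from compound 3 to compound 4 (0.04 log units; within the scatter) in size. Compound 4 is estimated at 12000 nM with 4500 nM and 30000 nM as the expected ends of its range.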

Compound 4, half-maximal inhibitory concentration: 5200 nM
Compound 4: the middle estimate sits 2.3-fold (0.36 log units) above what was measured; the measured number falls inside the stated range.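

In this assay, going by these compounds alone, this is the first change on the amide-type nitrogen to give a step beyond the scatter: a 2.1-fold lower number from compound 3 to compound 4 (0.33 log units; beyond the scatter). Cyclohexyl also separates from the (pyridin-2-yl)methyl group, with an at least 3.8-fold lower number from compound 2 to compound 4 (0.58 log units; beyond the scatter). Compound 1 goes less clearly with them, since an at least 1.9-fold lower number from compound 1 to compound 4 (0.28 log units; that floor lies within the scatter).

The compounds shown leave open whether the gain follows from the non-aromatic ring or from the ring sitting directly on the nitrogen. A phenyl or a cyclohexylmethyl group on this nitrogen would separate those two readings.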